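Isopropyl for methyl on the triazole of compound 3

A few compounds are considered here, and "the series" means these few. Any claim that something is new, unique, unknown or untested is made for them only; others in the source may bear on it.

Compound 1, `COC(=O)c1nc(C)n(-c2ccccc2)n1`: in a functional assay on NPC-TW01 cells (Homo sapiens) for inhibition, read by MTT assay, with a stated time of 72 h (on this read-out lower numbers stand for stronger inhibition of growth and higher numbers for weaker inhibition of growth), compound 1 gives only a limit, > 100000 nM.
Compound 2, `COC(=O)c1nc(C)n(-c2ccc(OC)cc2)n1`: in this assay compound 2 gives 9920 nM.
Compound 3, `COC(=O)c1nc(C)n(-c2ccc(F)cc2)n1`: in this assay compound 3 gives 15200 nM.

Among the numbers shown, compound 3 holds the highest, and its nearest neighbour is compound 2, with a 1.5-fold higher number from compound 2 to compound 3 (0.19 log units; within the scatter). The value of compound 1 is a limit of this assay and not a number. Compound 4, `COC(=O)c1nc(C(C)C)n(-c2ccc(F)cc2)n1`, differs from compound 3 only on the shared core: isopropyl in place of methyl on an aromatic carbon.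

Among the compounds with values here, none of the measured steps touches this group. The steps of an at least 10-fold lower number from compound 1 to compound 2 (1.00 log units; beyond the scatter) and an at least 6.5-fold lower number from compound 1 to compound 3 (0.81 log units; beyond the scatter) concern the substituent on the phenyl ring, which compound 4 keeps unchanged from compound 3. The comparison between compound 2 and compound 3 is also confined to that phenyl substituent. Within the data shown here, no step therefore speaks to a larger alkyl group on the core, and no change beyond the scatter is expected in this assay, in either direction.

Compound 4 is thus estimated at 15000 nM, within 5000 nM to 45000 nM, an expected step of a 1.0-fold lower number from compound 3 to compound 4 (0.01 log units; within the scatter).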

Compound 4, concentration for 50% growth inhibition: > 100000 nM
Compound 4 was reported as a limit (the forecaster's own chance of this, stated with the estimate: 10%); at least 6.6-fold (0.82 log units) between middle value and limit.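

Isopropyl in place of methyl on the aromatic carbon of the shared core gives an at least 6.5-fold higher number from compound 3 to compound 4 (0.81 log units; beyond the scatter), which shows that this place, untouched by the earlier steps, matters for growth inhibition in this assay. In this assay compound 4 gives > 100000 nM, which is a limit of the assay and not a number. The true size of the step therefore stays unknown, and the fluoro group that compound 3 carries does not keep compound 4 off the limit that compound 1 also shows: the limit of > 100000 nM in this assay, at which 2 of the 4 values shown sit.

What ethyl or a plain hydrogen would give on this carbon stays open, so the compounds shown do not tell how much alkyl the position tolerates. From the compounds shown here alone, it is also open whether isopropyl would have the same outcome with methoxy in place of fluoro on the phenyl ring.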